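Swapping a pyridine ring for a methoxyphenyl on a fused core

This account rests on a few compounds, and the source may have more. Where it says the series, first, only, none or still open, it means among the compounds named here.

Two compounds have been prepared on a shared core, and a third is awaited. Compound 1 `COc1ccc2c(OCc3nnc4sc(-c5cc6cc(F)ccc6[nH]5)nn34)ccnc2c1` carries a fluorinated indole on that core; in a functional assay on EBC-1 cells (Homo sapiens) for antiproliferative activity, with a stated time of 72 h (on this read-out higher numbers stand for weaker inhibition and lower numbers for stronger inhibition), compound 1 gives "not determined" (no result reported), so no number is available for it. Compound 2 `COc1ccc2c(OCc3nnc4sc(-c5ccncc5)nn34)ccnc2c1` carries a pyridin-4-yl there instead; in this assay compound 2 gives 289 nM, which is the only number shown in this series, so it cannot be ranked against anything else.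

Compound 3 `COc1ccc(-c2nn3c(COc4ccnc5cc(OC)ccc45)nnc3s2)cc1` is the next step. It differs from compound 2 in one place: 4-methoxyphenyl in place of pyridin-4-yl on an aromatic carbon. No change between two measured compounds is available to calibrate what such a swap does on this core, so the expectation rests on compound 2 alone. Since nothing in the data points one way or the other, the step from compound 2 to compound 3 is expected to be small, a 1.4-fold lower number from compound 2 to compound 3 (0.16 log units; within the scatter), and may not exceed the usual scatter of repeated runs. For compound 3 the estimated value in this assay is 200 nM, with a plausible range from 50 nM to 800 nM.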

Compound 3, half-maximal inhibitory concentration: 161 nM
Compound 3: middle estimate off by 1.2-fold (0.09 log units), on the high side, within the range that was stated.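

In this assay the exchange of pyridin-4-yl for 4-methoxyphenyl gives a 1.8-fold lower number from compound 2 to compound 3 (0.25 log units; within the scatter) and stays within the scatter of repeated measurements, so compound 2 and compound 3 cannot be told apart on this read-out. Going by these compounds alone, this is the first readable step on the shared core: at this aromatic carbon, a six-membered aromatic ring of carbon only, carrying a methoxy group, can stand in place of a six-membered aromatic ring with a ring nitrogen without a step beyond that scatter, although this rests on a single pair. No independent measurement is available to explain the closeness of the two values.

The steps to compound 1 cannot be read, so the fluorinated indole on the shared core remains unplaced against the two six-membered rings. Both groups compared here are uncharged aromatic rings, which leaves open what this position would do with a quite different group, such as a carboxylic acid, an amine or a longer alkyl chain.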